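From 2,6-dimethylphenyl to 2-chlorophenyl in a cytotoxicity series

This account rests on a few compounds, and the source may have more. Where it says the series, first, only, none or still open, it means among the compounds named here.

For the measured compounds named here, in a functional assay on BT-483 cells (Homo sapiens) for cytotoxicity, read by MTT assay, with a stated time of 24 h (on this read-out higher numbers stand for weaker inhibition and lower numbers for stronger inhibition), compound 3 `CCNc1cc(-c2ccc(NC(=O)Nc3c(C)cccc3C)cc2C(F)(F)F)ccn1` gives 22000 nM as the only true number in the set. Compound 1 `CCNc1cc(-c2ccc(NC(=O)Nc3ccccc3Cl)cc2C)ccn1` gives > 30000 nM as a limit of the assay. Compound 2 `CCNc1cc(-c2ccc(NC(=O)Nc3cccc4ccccc34)cc2C(F)(F)F)ccn1` gives > 30000 nM as a limit of the assay too. Compound 3 thus stands alone beside the limit of > 30000 nM in this assay, at which 2 of the 3 values shown sit, in this small set.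

Compound 4 `CCNc1cc(-c2ccc(NC(=O)Nc3ccccc3Cl)cc2C(F)(F)F)ccn1` has not yet been measured. The change from compound 3 is 2-chlorophenyl in place of 2,6-dimethylphenyl on an amide-type nitrogen and puts 2-chlorophenyl in place of 2,6-dimethylphenyl on an amide-type nitrogen. Going by the values given here, the one measured step at this place is an at least 1.3-fold lower number from compound 2 to compound 3 (0.13 log units; that floor lies within the scatter) and it gives only a floor, so it says little about size. Compound 1 also holds 2-chlorophenyl on an amide-type nitrogen, and its > 30000 nM is a limit. The expected change in this assay is therefore none beyond the scatter, with a slight lean towards a higher number because of the limit > 30000 nM of compound 1 in that same assay. The estimated move is a 1.2-fold higher number from compound 3 to compound 4 (0.07 log units; within the scatter) and is expected to stay within the scatter. Compound 4 is estimated at 26000 nM with an expected range from 13000 nM to 45000 nM and could well be only a limit of the assay.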

Compound 4, half-maximal inhibitory concentration: 20800 nM
The estimate for compound 4 lay 1.3-fold (0.10 log units) above the measured number, within the range that was stated.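

In this assay, for the compounds shown here, 2-chlorophenyl in place of 2,6-dimethylphenyl on an amide-type nitrogen gives a 1.1-fold lower number from compound 3 to compound 4 (0.02 log units; within the scatter), so at this place the two groups cannot be told apart, and this is the first step here that rests on two true numbers. The other two steps can be read only as floors: 2-chlorophenyl in place of naphthalen-1-yl gives an at least 1.4-fold lower number from compound 2 to compound 4 (0.15 log units; that floor lies within the scatter), and trifluoromethyl in place of methyl on an aromatic carbon gives an at least 1.4-fold lower number from compound 1 to compound 4 (0.15 log units; that floor lies within the scatter). Neither floor shows a real difference, and each of these steps starts from a limit of the assay, so its true size stays unknown: the limit of > 30000 nM in this assay, at which 2 of the 4 values shown sit.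

As far as these compounds go, how large the step from methyl to trifluoromethyl really is therefore stays open, as does the true place of naphthalen-1-yl against 2-chlorophenyl. The compounds shown carry only aromatic groups on the amide-type nitrogen, so it also stays open whether a piperidine or a carboxylic acid on a longer chain at that place would move the number beyond the scatter in this assay.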